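A Bromophenyl Swap on Compound 3

The compounds below may be only part of what the source reports. "The series", "measured", "known", "first", "only" and "open" are said of these compounds alone.

In a functional assay on UACC-62 cells (Homo sapiens) (on this read-out higher numbers stand for weaker inhibition of growth and lower numbers for stronger inhibition of growth), compound 1 `O=S(=O)(/C=C/c1ccc(Cl)cc1Cl)Cc1ccc(Nc2ncnc3ccc(Br)cc23)cc1` gives 2000 nM. Compound 2 `O=S(=O)(/C=C/c1ccc(C(F)(F)F)cc1F)Cc1ccc(Nc2ncnc3cc(Cl)ccc23)cc1` gives > 100000 nM, which is a limit of the assay and not a number. Compound 3 `COc1cc2ncnc(Nc3ccc(CS(=O)(=O)/C=C/c4ccc(Cl)cc4Cl)cc3)c2cc1OC` gives 21000 nM, the higher of the two actual numbers, and its gap to compound 1 lies beyond the usual scatter of repeated measurements. Compound 4 `COc1cc2ncnc(Nc3ccc(CS(=O)(=O)/C=C/c4ccc(Br)cc4)cc3)c2cc1OC` carries 4-bromophenyl in place of 2,4-dichlorophenyl on a double-bonded chain carbon bound to a double-bonded chain carbon. Within the data shown here, no pair of measured compounds shows this single change, so no direction is favoured, and no shift beyond the scatter is expected in this assay. The expected change is a 1.1-fold lower number from compound 3 to compound 4 (0.02 log units; within the scatter). In this assay, the estimate for compound 4 is 20000 nM, with an expected range of 6000 nM to 70000 nM.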

Compound 4, concentration for 50% growth inhibition: 63000 nM
Beside the measured number, compound 4's estimate is 3.2-fold (0.50 log units) below it; the range from low to high includes it.
By their numbers in this assay, from the lowest: compound 1; then compound 3; then compound 4. At a limit, above all of these: compound 2.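

In this assay, 4-bromophenyl in place of 2,4-dichlorophenyl gives a 3.0-fold higher number from compound 3 to compound 4 (0.48 log units; beyond the scatter) and so weaker inhibition of growth. This is the first single-place change shown, and it indicates that the group on this double-bonded chain carbon can alter the read-out, though only modestly. No measurement shown accounts for this step. The change alters both halogen type and halogen count, so these two contributions cannot be separated. On these data alone, how a phenyl ring carrying an amine or a carboxylic acid would behave at this place remains open.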